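The compounds below may be only part of what the source reports. "The series", "measured", "known", "first", "only" and "open" are said of these compounds alone.

Three compounds share one core, and they differ only in the aryl group on a nitrogen on an aromatic ring. Compound 1 `Cc1cc(=O)oc2cc(OCc3nc(N)nc(Nc4cccc(Cl)c4)n3)ccc12` carries a 3-chlorophenyl there; in an assay on COS-7 cells for agonist activity at Free fatty acid receptor 1 (Homo sapiens), read by scintillation counting and inositol phosphate accumulation, with a stated time of 90 min (a lower number here means that less compound is needed, a higher number that more compound is needed for the effect), compound 1 gives 1110 nM. Compound 2 `Cc1cc(=O)oc2cc(OCc3nc(N)nc(Nc4ccc(C(C)C)cc4)n3)ccc12` carries a 4-isopropylphenyl, and in this assay compound 2 gives 460 nM. Compound 3 `Cc1ccc(Nc2nc(N)nc(COc3ccc4c(C)cc(=O)oc4c3)n2)cc1C` carries a 3,4-dimethylphenyl, and in this assay compound 3 gives 210 nM. Among these three numbers, compound 1 stands highest: the step of a 2.4-fold lower number from compound 1 to compound 2 (0.38 log units; beyond the scatter) and the step of a 5.3-fold lower number from compound 1 to compound 3 (0.72 log units; beyond the scatter) both run downward, and the step of a 2.2-fold lower number from compound 2 to compound 3 (0.34 log units; beyond the scatter) shows that the dimethyl-bearing compound sits lowest.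

Compound 4 `Cc1cc(Nc2nc(N)nc(COc3ccc4c(C)cc(=O)oc4c3)n2)ccc1Cl` has not yet been measured. It differs from compound 1 in one place: 4-chloro-3-methylphenyl in place of 3-chlorophenyl on a nitrogen on an aromatic ring. The chlorine is kept and a methyl is added, so the change sits between what was seen in the steps above. Both measured steps away from 3-chlorophenyl lowered the number by a modest margin, beyond the scatter but not by much. A similar modest lowering is therefore expected here, and the step of a 2.6-fold lower number from compound 1 to compound 4 (0.42 log units; beyond the scatter) is the estimate. Compound 4 is expected to give about 420 nM in this assay, within a range from 150 nM to 1200 nM.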

Compound 4, half-maximal effective concentration: 240 nM
Estimate against measurement, compound 4: 1.8-fold (0.24 log units) above; the measured number falls inside the stated range.
By their numbers in this assay, from the lowest: compounds 3, 4 and 2 (each within the scatter of the next, the first and the last beyond it); then compound 1.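

Keeping the chlorine does not keep the high number: compound 4 still carries a chlorine on its aryl group, yet the move from 3-chlorophenyl to 4-chloro-3-methylphenyl gives a clear drop (a 4.6-fold lower number from compound 1 to compound 4 (0.67 log units; beyond the scatter)), so a chlorine alone does not set compound 1 apart in this assay. Chloro in place of methyl on an aromatic carbon makes no readable difference (a 1.1-fold higher number from compound 3 to compound 4 (0.06 log units; within the scatter)), so at this spot on the ring the two groups cannot be told apart here, and the 4-chloro-3-methylphenyl and 3,4-dimethylphenyl compounds stand level. The 4-isopropylphenyl compound also cannot be separated from compound 4 (a 1.9-fold lower number from compound 2 to compound 4 (0.28 log units; within the scatter)), even though compound 2 and compound 3 do differ beyond the scatter, so the three groups form a loose cluster rather than a clean order, with compound 1 alone standing apart.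

All four aryl groups carry only chloro or simple alkyl groups, which leaves open how the number would respond to a methoxy group, an amine, a carboxylic acid or a longer alkyl chain at this position. Nothing measured here explains why these aryl groups give the numbers they do.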